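A Methyl-to-Hydrogen Swap on a Chloropyridine Amide

This account rests on a few compounds, and the source may have more. Where it says the series, first, only, none or still open, it means among the compounds named here.

In a functional assay on WM 266-4 cells (Homo sapiens) for antiproliferative activity, read by MTT assay, with a stated time of 24 h (on this read-out lower numbers stand for stronger inhibition of growth and higher numbers for weaker inhibition of growth), three compounds have been measured:
compound 1, `COc1ccc(C2=NN(C(=O)c3ccc(C)nc3Cl)C(c3ccc(OC)cc3)C2)cc1`, gives 5740 nM
compound 2, `COc1ccc(C2=NN(C(=O)c3cccnc3Cl)C(c3ccc(OC)cc3)C2)cc1`, gives 4350 nM
compound 3, `Cc1ccc(C(=O)N2N=C(c3ccc(Cl)cc3)CC2c2ccc(OCc3ccccc3)cc2)c(Cl)n1`, gives 11400 nM

Compound 1 and compound 2 share a core and differ only in one spot: hydrogen in place of methyl on an aromatic carbon. That change made a step of a 1.3-fold lower number from compound 1 to compound 2 (0.12 log units; within the scatter), so the two compounds cannot be told apart on this read-out. Compound 3 carries a different core; how its core differs from that of compound 1 is not broken down here. Its number is higher than that of compound 2 by more than the usual scatter, while against compound 1 the two values lie within the scatter of each other.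

Compound 4, `O=C(c1cccnc1Cl)N1N=C(c2ccc(Cl)cc2)CC1c1ccc(OCc2ccccc2)cc1`, is built from compound 3 by the same change, (hydrogen in place of methyl on an aromatic carbon), at the same place. Because the earlier step of a 1.3-fold lower number from compound 1 to compound 2 (0.12 log units; within the scatter) stayed within the scatter, a step of a 1.3-fold lower number from compound 3 to compound 4 (0.11 log units; within the scatter) is expected here as well. Compound 4 is therefore estimated to give about 8800 nM in this assay , with a plausible range from 3500 nM to 22000 nM.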

Compound 4, concentration for 50% growth inhibition: 7710 nM
For compound 4 the middle estimate is 1.1-fold (0.06 log units) above the measured one; measured number inside the range.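

On the second core, putting hydrogen in place of methyl gives a 1.5-fold lower number from compound 3 to compound 4 (0.17 log units; within the scatter) in this assay, so this pair, like the first, cannot be told apart on this read-out. The change therefore carries over from one core to the other with a similar, small result: the same change on two cores in this assay, a 1.3-fold lower number (0.12 log units; within the scatter) from compound 1 to compound 2 and a 1.5-fold lower number (0.17 log units; within the scatter) from compound 3 to compound 4, 1.1-fold (0.05 log units) apart, within the scatter of two such steps. This shows that losing this methyl made no measurable difference on either of these two cores, but two pairs in a single cell assay do not show that the same would hold on other cores or in other assays, and they do not explain why the step is so small.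

Methyl and hydrogen are the only groups shown at this carbon, so it remains open whether a larger or different group there, such as an ethyl chain, a methoxy group, an amine or a carboxylic acid, would move the number beyond the scatter. Also open, on these data alone, is what would happen if the chloro group on the same ring were replaced, for example by hydrogen or a fluoro group.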